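The compounds below may be only part of what the source reports. "The series", "measured", "known", "first", "only" and "open" are said of these compounds alone.

Compound 1 `CS(=O)(=O)c1ccc(N2CCc3c(OC4CCN(C(=O)OCCF)CC4)ncnc32)c(F)c1` gives 501 nM in a functional assay on CHO-K1 cells for agonist activity at Glucose-dependent insulinotropic receptor (Homo sapiens), read by a luciferase reporter, with a stated time of 5 h; on this read-out lower numbers stand for an effect already at smaller amounts and higher numbers for an effect only at larger amounts of compound. Compound 2 `CN(C)C(=O)CN1CCC(Oc2ncnc3c2CCN3c2ccc(S(C)(=O)=O)cc2F)CC1` is reported in this assay only as a limit, > 10000 nM. Compound 2 therefore stands at the limit of > 10000 nM in this assay, at which 1 of the 2 values shown sits, with no measured number of its own. Going by the values given here, the one measured step between these compounds, an at least 19-fold higher number from compound 1 to compound 2 (1.30 log units; beyond the scatter), shows that exchanging the group on the amine nitrogen in the ring can shift the read-out by a large amount. Compound 3 `CC(C)c1noc(N2CCC(Oc3ncnc4c3CCN4c3ccc(S(C)(=O)=O)cc3F)CC2)n1` differs from compound 2 in that same place: 3-isopropyl-1,2,4-oxadiazol-5-yl in place of (dimethylcarbamoyl)methyl on an amine nitrogen in a ring. Among the compounds with values here, the single measured step gives the size that such an exchange can reach but does not fix its direction for this new group. An improvement is nonetheless expected for compound 3 because an at least 19-fold higher number from compound 1 to compound 2 (1.30 log units; beyond the scatter) marks this position as one where the substituent matters greatly. The expected step is an at least 6.6-fold lower number from compound 2 to compound 3 (0.82 log units; beyond the scatter). Compound 3 is estimated at 1500 nM, within a range from 200 nM to 10000 nM.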

Compound 3, half-maximal effective concentration: 79.4 nM
Compound 3: middle estimate off by 19-fold (1.28 log units), on the high side, and the stated range ends above it.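

Going by these compounds alone, the earlier compounds showed only that a change in the group on the amine nitrogen in the ring could raise the number in this assay; compound 3 shows that a change there can also lower it sharply, with an at least 120-fold lower number from compound 2 to compound 3 (2.10 log units; beyond the scatter). The size of that step is only a bound, since compound 2 stands as a limit and not as a number: the limit of > 10000 nM in this assay, at which 1 of the 3 values shown sits. The 3-isopropyl-1,2,4-oxadiazol-5-yl group also improves on the (2-fluoroethoxy)carbonyl group, with a 6.3-fold lower number from compound 1 to compound 3 (0.80 log units; beyond the scatter), so the carbonyl of compound 1 is not required at this position for an effect in this assay.

The compounds shown do not separate the contribution of the five-membered aromatic ring from that of its isopropyl. On these data alone, it also remains open whether a cyclopropyl or a tert-butyl in place of the isopropyl would keep or lower the number.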